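A few compounds are considered here, and "the series" means these few. Any claim that something is new, unique, unknown or untested is made for them only; others in the source may bear on it.

In a physicochemical assay for solubility, in phosphate buffer, measured as kinetic solubility, at pH 7.4 (on this read-out higher numbers stand for higher solubility and lower numbers for lower solubility), two compounds sharing one core have been measured so far. Compound 1 `COc1cccc(Cl)c1-c1nc(CN2CCC(C(=O)NCCCN3C[C@H](C)C[C@H](C)C3)CC2)c(C)o1` gives > 76 ug/mL, which is a limit of the assay and not a number. Compound 2 `COc1cccc(C)c1-c1nc(CN2CCC(C(=O)NCCCN3C[C@H](C)C[C@H](C)C3)CC2)c(C)o1` gives > 73 ug/mL, and this too is only a limit. Going by the values given here, the single measured step is a step that the two limits leave unreadable from compound 1 to compound 2, with methyl in place of chloro on an aromatic carbon. Compound 3 `Cc1ccc(-c2nc(CN3CCC(C(=O)NCCCN4C[C@H](C)C[C@H](C)C4)CC3)c(C)o2)c(C)c1` differs from compound 2 in the whole aryl group: 2,4-dimethylphenyl in place of 2-methoxy-6-methylphenyl on an aromatic carbon. The step that the two limits leave unreadable from compound 1 to compound 2 bears on this change only loosely and supplies no size to carry over, so no step beyond the scatter is expected in this assay, in either direction. The estimated step is an at least 1.0-fold lower number from compound 2 to compound 3 (0.03 log units; that floor lies within the scatter). For compound 3 the expected solubility is 68 ug/mL, with an estimated range of 35 ug/mL to 80 ug/mL.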

Compound 3, solubility: > 71 ug/mL
Compound 3 was reported as a limit; the forecaster's own chance of this, stated with the estimate: 70%; middle value at least 1.0-fold (0.01 log units) from the limit.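

In this assay compound 3 gives > 71 ug/mL, which is a limit and not a number, and the steps linking compound 1, compound 2 and compound 3 cannot be read. The compounds shown leave open the actual value of each compound and whether the three differ at all.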